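This account rests on a few compounds, and the source may have more. Where it says the series, first, only, none or still open, it means among the compounds named here.

Compound 3 `CC(=O)Nc1cnc(N2CCN(C3CCN(Cc4ccc(Cl)cc4)CC3)[C@@H](C)C2)c(Cl)c1` gives 8 nM in a functional assay for antagonist activity at C-X-C chemokine receptor type 3 (Homo sapiens) (a higher number here means a weaker inhibitor, a lower number a stronger inhibitor), the lowest of the three values measured. Compound 1 `CC1(N2CCN(c3ncc(C(=O)NCc4ccc(Cl)c(Cl)c4)cc3Cl)CC2)CCN(Cc2ccc(Cl)cc2)CC1` gives 27 nM, and compound 2 `CC(=O)c1cnc(N2CCN(C3CCN(Cc4ccc(Cl)cc4)CC3)[C@@H](C)C2)c(Cl)c1` gives 520 nM. Among the compounds with values here, the only measured step that changes one place, a 65-fold lower number from compound 2 to compound 3 (1.81 log units; beyond the scatter), came from acetamido replacing acetyl. Compound 4 `C[C@H]1CN(c2ncc(C(=O)Nc3ccc(F)c(F)c3)cc2Cl)CCN1C1CCN(Cc2ccc(Cl)cc2)CC1` differs from compound 3 by (3,4-difluorophenyl)carbamoyl in place of acetamido on an aromatic carbon. This removes the acetamido present in compound 3 and installs a carbamoyl bearing a difluorophenyl ring, a kind of amide also found, with a different ring attached, in compound 1. Since compound 1 reaches 27 nM with such an amide, compound 4 is expected to land near 30 nM, a step of a 3.8-fold higher number from compound 3 to compound 4 (0.57 log units; beyond the scatter), within 8 nM to 120 nM.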

Compound 4, half-maximal inhibitory concentration: 22 nM
Beside the measured number, compound 4's estimate is 1.4-fold (0.13 log units) above it; measured number inside the range.
By their numbers in this assay, from the lowest: compound 3; then compounds 4 and 1 (each within the scatter of the next); then compound 2.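

At this position, on an aromatic carbon two atoms from the ring nitrogen, the much larger (3,4-difluorophenyl)carbamoyl, with its added aromatic ring, costs little compared with acetamido: a 2.8-fold higher number from compound 3 to compound 4 (0.44 log units; beyond the scatter) is only a modest step. Replacing the methyl on the carbonyl carbon of the acetyl group with (3,4-difluorophenyl)amino gives a 24-fold lower number from compound 2 to compound 4 (1.37 log units; beyond the scatter), so a second kind of amide also far outperforms acetyl. Nothing available explains either step. From the compounds shown here alone, what a carboxylic acid or an amine at this position would give in this assay remains open. So does whether the two fluorines on the new ring matter.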